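The source may report more compounds than this note shows. Statements on the series, on what has been measured and on what is new or still open speak of the compounds shown alone.

Measured compounds:
Compound 1 `O=c1[nH]cnc2c1c(-c1ccoc1)cn2[C@@H]1O[C@H](CO)[C@@H](O)[C@H]1O` — > 20000 nM
Compound 2 `O=c1[nH]cnc2c1c(-c1ccsc1)cn2[C@@H]1O[C@H](CO)[C@@H](O)[C@H]1O` — > 20000 nM

In a functional assay on A549 cells (Homo sapiens), read by MTT assay, with a stated time of 72 h (a lower number here means a stronger inhibitor, a higher number a weaker inhibitor), compound 1 gives > 20000 nM, which is a limit of the assay and not a number. Compound 2 likewise gives > 20000 nM in this assay, again a limit rather than a measured number. The step that the two limits leave unreadable from compound 1 to compound 2 therefore cannot be read in size, as the limit of > 20000 nM in this assay, at which 2 of the 2 values shown sit, shows. Compound 2 thus stands only at a limit, with no number behind it and nothing in this assay that places it against compound 1.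

Compound 3 `O=c1[nH]cnc2c1c(-c1ccco1)cn2[C@@H]1O[C@H](CO)[C@@H](O)[C@H]1O` carries furan-2-yl in place of thiophen-3-yl on an aromatic carbon. For the measured compounds named here, the only measured step between compounds differing in one place gives no size, so no readable step bears on this change. Going by the values given here, the expectation is that compound 3 shows no step beyond the scatter, a step that the limit leaves unreadable from compound 2 to compound 3, and sits at the limit again, because both values known so far sit there (the limit of > 20000 nM in this assay, at which 2 of the 2 values shown sit). Compound 3 is estimated at 30000 nM, between 10000 nM and 100000 nM.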

Compound 3, half-maximal inhibitory concentration: > 20000 nM
Compound 3 ended at the assay's limit (the forecaster's own chance of this, stated with the estimate: 85%); the middle value is on the limit's open side.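

For the compounds shown here, compound 3 also stands only at a limit, so no step among compound 1, compound 2 and compound 3 can be read in size: the limit of > 20000 nM in this assay, at which 3 of the 3 values shown sit. The compounds shown leave open whether any group at this place on the shared core would give a measurable value in this assay.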